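A few compounds are considered here, and "the series" means these few. Any claim that something is new, unique, unknown or untested is made for them only; others in the source may bear on it.

For the measured compounds named here, compound 3 `O=C(COc1ccc(/C=C2\SC(=O)NC2=O)cc1)Nc1ccc(Br)cc1` stands alone as the one measured compound with a number in a functional assay on PC-3 cells (Homo sapiens) for inhibition; a higher number here means a weaker inhibitor of growth, a lower number a stronger inhibitor of growth: compound 3 gives 86600 nM. Compound 1 `O=C(COc1ccc(/C=C2\SC(=O)NC2=O)cc1)Nc1ccc([N+](=O)[O-])cc1` reaches only the assay limit of > 100000 nM. Compound 2 `O=C(COc1ccc(/C=C2\SC(=O)NC2=O)cc1)Nc1cccc([N+](=O)[O-])c1` likewise reaches only the limit of > 100000 nM. The change a step that the two limits leave unreadable from compound 1 to compound 2 cannot be sized because of the limit of > 100000 nM in this assay, at which 2 of the 3 values shown sit. The steps of an at least 1.1-fold lower number from compound 1 to compound 3 (0.06 log units; that floor lies within the scatter) and an at least 1.1-fold lower number from compound 2 to compound 3 (0.06 log units; that floor lies within the scatter) are floors that lie within the scatter.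

Compound 4 `Cc1ccc(NC(=O)COc2ccc(/C=C3\SC(=O)NC3=O)cc2)cc1Cl` differs from compound 3 by 3-chloro-4-methylphenyl in place of 4-bromophenyl on an amide-type nitrogen. Going by the values given here, none of the measured steps swaps one halogen-bearing phenyl for another, so they give no direction for this step. Compound 4 is therefore expected to sit near compound 3, a step of a 1.1-fold lower number from compound 3 to compound 4 (0.03 log units; within the scatter) at most within the scatter. The estimate for compound 4 is 80000 nM, in the range 30000 nM to 200000 nM.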

Compound 4, concentration for 50% growth inhibition: > 100000 nM
Compound 4: a limit, no number (the forecaster's own chance of this, stated with the estimate: 35%); middle value at least 1.2-fold (0.09 log units) from the limit.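

Placing 3-chloro-4-methylphenyl on the amide-type nitrogen in place of 4-bromophenyl gives an at least 1.1-fold higher number from compound 3 to compound 4 (0.06 log units; that floor lies within the scatter), so this change brings no readable gain in this assay. For the compounds shown here, compound 4 gives a limit and not a number, which leaves 4-bromophenyl as the only group here with a number, though its edge over the others stays within the scatter. The steps to compound 4 from compound 1 and from compound 2 cannot be read: the limit of > 100000 nM in this assay, at which 3 of the 4 values shown sit.

On these data alone, it remains open whether any group on this nitrogen gives clearly stronger growth inhibition. A phenyl carrying an amine or a carboxylic acid could still behave differently.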